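This account rests on a few compounds, and the source may have more. Where it says the series, first, only, none or still open, it means among the compounds named here.

Among the measured compounds shown here, compound 3 `CC(C)(C)c1ccc(OC(=O)c2cn(-c3ccccc3)nc2-c2ccncc2)cc1` is the only member of the series with a number in a functional assay on MDA-MB-231 cells (Homo sapiens) for cytotoxicity, read by MTT assay, with a stated time of 48 h; on this read-out higher numbers stand for weaker inhibition and lower numbers for stronger inhibition: compound 3 gives 34500 nM. Compound 1 `CCc1ccc(OC(=O)c2cn(-c3ccccc3)nc2-c2ccncc2)cc1` sits at the limit of this assay, > 100000 nM. Compound 2 `CC(C)c1cccc(OC(=O)c2cn(-c3ccccc3)nc2-c2ccncc2)c1` likewise sits at the limit, > 100000 nM. Both an at least 2.8-fold lower number from compound 1 to compound 3 (0.46 log units; beyond the scatter) and an at least 2.8-fold lower number from compound 2 to compound 3 (0.46 log units; beyond the scatter) run towards compound 3, while a step that the two limits leave unreadable from compound 1 to compound 2 cannot be sized, both partners standing at the limit of > 100000 nM in this assay, at which 2 of the 3 values shown sit. Compound 4 `O=C(O)c1cn(-c2ccccc2)nc1-c1ccncc1` differs from compound 3 by hydrogen in place of 4-(tert-butyl)phenyl on an oxygen next to a carbonyl group, the ester giving way to the free acid. For the measured compounds named here, no measured step removes the aryl ester altogether, so the outlook rests only on the smaller esters of compound 1 and compound 2 returning to the limit. Compound 4 is therefore expected to fall back to the limit as well, estimated at 150000 nM within 30000 nM to 1000000 nM, an expected step of a 4.3-fold higher number from compound 3 to compound 4 (0.64 log units; beyond the scatter).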

Compound 4, half-maximal inhibitory concentration: > 100000 nM
Compound 4 ended at the assay's limit (the forecaster's own chance of this, stated with the estimate: 75%); the middle value does not contradict the limit.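

Among the compounds shown here, on the oxygen next to a carbonyl group, hydrogen in place of 4-(tert-butyl)phenyl gives an at least 2.8-fold higher number from compound 3 to compound 4 (0.46 log units; beyond the scatter) in this assay, so the free acid does not keep the one measurable reading. Compound 4 stands at a limit of the assay, > 100000 nM, not at a number. The steps to compound 4 from compound 1 and compound 2 cannot be read, and these three compounds cannot be ranked, because each stands at the limit: the limit of > 100000 nM in this assay, at which 3 of the 4 values shown sit.

Open, from the compounds shown here alone, is whether an amide in place of the ester would keep the reading of compound 3. Also open, going by these compounds, is whether an adamantyl group in place of tert-butyl would shift it.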